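The source may hold more compounds than are shown below. What is called first, only, known or untested is meant among the compounds shown, and "the series" means these compounds.

Among the compounds with values here, the three compounds measured so far share one core and differ at the phenoxy end of the pendant aryl ring and at the aryl group on the ring nitrogen. Compound 1 `COc1cc([C@H]2S[C@@H](C)C(=O)Nc3c2c(C)nn3-c2ccccc2C)ccc1Oc1ccccc1` carries a methoxy next to the phenoxy link; in an assay on isolated protein for agonist activity at Bile acid receptor (Homo sapiens), read by AlphaScreen, with a stated time of 30 min (a lower number here means that less compound is needed, a higher number that more compound is needed for the effect), compound 1 gives 1900 nM. Compound 2 `COc1ccc(Oc2ccc([C@H]3S[C@@H](C)C(=O)Nc4c3c(C)nn4-c3ccccc3C)cc2)cc1` instead carries a 4-methoxyphenoxy group, and in this assay compound 2 gives 2200 nM. Compound 3 `Cc1nn(-c2ccccc2Br)c2c1C(c1ccc(Oc3ccccc3)cc1)SC(C)C(=O)N2` pairs a plain phenoxy group with a bromophenyl on the ring nitrogen; in this assay compound 3 gives 1800 nM. Compound 2 holds the highest of the three numbers, yet its distances to compound 1 and to compound 3 both sit within the scatter, so the three are indistinguishable on these data.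

Compound 4 `Cc1ccccc1-n1nc(C)c2c1NC(=O)[C@H](C)S[C@@H]2c1ccc(OCc2ccccc2)cc1` is the untested member. Relative to compound 2 the change is benzyl in place of 4-methoxyphenyl on an oxygen on an aromatic ring. Within the data shown here, no measured pair shows this exchange, so the expected step of a 1.1-fold higher number from compound 2 to compound 4 (0.06 log units; within the scatter) is small, with no clear direction beyond the scatter. Compound 4 is therefore estimated at 2500 nM, within 800 nM to 8000 nM.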

Compound 4, half-maximal effective concentration: "not active" (no number reported)
Compound 4 has no reported number here, and the estimate cannot be compared.
By their numbers in this assay, from the lowest: compounds 3, 1 and 2 (each within the scatter of the next).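

Within the data shown here, compound 4 is reported in this assay without a number, so no step from compound 2 to compound 4 can be read. The compounds shown leave open how benzyloxy in place of 4-methoxyphenoxy changes the response. No evidence given here bears on this result.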